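Amide to Sulfone: One Change and One Expected Number

The source may hold more compounds than are shown below. What is called first, only, known or untested is meant among the compounds shown, and "the series" means these compounds.

Compound 1 `CN(C)C(=O)c1cccc(C#Cc2cc(Cl)ccc2OCC(=O)O)c1` was tested in an assay on CHO cells for displacement of a labelled ligand from prostaglandin D2 receptor 2 (Homo sapiens), read by scintillation counting (a lower number here means a stronger inhibitor, a higher number a weaker inhibitor), where compound 1 gives 52 nM. Among the measured compounds shown here, that is the lowest of the two numbers known so far. For the measured compounds named here, the only other measured compound, compound 2 `O=C(O)COc1cc(F)ccc1C#Cc1ccccc1Cl`, gives 4780 nM in this assay. Going by the values given here, compound 2 differs from compound 1 in more than one place, so the two values show only that compound 1 is the stronger inhibitor of the pair, by a gap well beyond the usual scatter. Among the compounds with values here, no step between measured compounds that differ in a single place is available.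

Compound 3 `CS(=O)(=O)Cc1cccc(C#Cc2cc(Cl)ccc2OCC(=O)O)c1` has not been measured yet. It differs from compound 1 in one place: (methylsulfonyl)methyl in place of dimethylcarbamoyl on an aromatic carbon. Within the data shown here, nothing among the measured compounds shows how such a swap moves the number in this assay. The expectation is therefore a modest step of a 1.6-fold higher number from compound 1 to compound 3 (0.21 log units; within the scatter), toward a slightly higher number, and quite possibly within the scatter. Compound 3 is expected to give 85 nM in this assay. The estimate for compound 3 should be read with a range from 20 nM to 400 nM.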

Compound 3, inhibition constant: 48 nM
Compound 3: middle estimate off by 1.8-fold (0.25 log units), on the high side; the measured number falls inside the stated range.
By their numbers in this assay, from the lowest: compounds 3 and 1 (each within the scatter of the next); then compound 2.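

In this assay, putting (methylsulfonyl)methyl in place of dimethylcarbamoyl on this aromatic carbon gives a 1.1-fold lower number from compound 1 to compound 3 (0.03 log units; within the scatter), so the two compounds cannot be told apart. Among the compounds shown here, this is the first comparison here that isolates a single place, which the pair of compound 1 and compound 2 could not do, and it shows that this position accepts two groups of different make-up with no change beyond the scatter: both have the same number of heavy atoms, but one holds nitrogen and a carbonyl, while the other holds sulfur and a sulfonyl. No measurement at hand explains why the number stays put.

On these data alone, what remains open is how far this tolerance extends, since a single swap cannot show whether a basic amine, a carboxylic acid or a longer chain such as (ethylsulfonyl)methyl at the same position would also leave the number unchanged. It is also unknown whether this swap would give a similar result on a core carrying a different halogen or a different arrangement of groups.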